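The compounds below may be only part of what the source reports. "The series", "measured", "known", "first", "only" and "open" are said of these compounds alone.

Of the compounds shown here, two share one core and have been tested in a functional assay on HepG2 cells (Homo sapiens) for cytotoxicity, read by MTT assay, with a stated time of 72 h; on this read-out lower numbers stand for stronger inhibition and higher numbers for weaker inhibition. Compound 1 `Cc1cc(=O)n(-c2ccccc2C(F)(F)F)nc1C(=O)Nc1ccc(Oc2ncnc3sccc23)c(F)c1` gives 14700 nM. Compound 2 `Cc1cc(=O)n(-c2ccc(F)cc2)nc1C(=O)Nc1ccc(Oc2ncnc3sccc23)c(F)c1`, which carries a 4-fluorophenyl in place of the 2-(trifluoromethyl)phenyl on the aromatic nitrogen, gives 12500 nM. For the measured compounds named here, the step between them, a 1.2-fold lower number from compound 1 to compound 2 (0.07 log units; within the scatter), is within the scatter, so compound 2 sits alongside compound 1 rather than apart from it; there are only these two numbers so far.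

Compound 3 `Cc1cc(=O)n(-c2ccc(F)c(F)c2)nc1C(=O)Nc1ccc(Oc2ncnc3sccc23)c(F)c1` differs from compound 2 by fluoro in place of hydrogen on an aromatic carbon. Going by the values given here, the only measured step, from compound 1 to compound 2, also altered the ring on the aromatic nitrogen and produced no change beyond the scatter. On that single precedent, compound 3 is expected to land close to compound 2, with a step of about a 1.0-fold higher number from compound 2 to compound 3 (0.02 log units; within the scatter) in this assay. The estimate for compound 3 is therefore 13000 nM, expected to fall between 5500 nM and 30000 nM.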

Compound 3, half-maximal inhibitory concentration: > 40000 nM
Compound 3: a limit, no number; the forecaster's own chance of this, stated with the estimate: 5%; at least 3.0-fold (0.48 log units) between middle value and limit.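

In this assay, the change from 4-fluorophenyl to 3,4-difluorophenyl, a single fluoro placed ortho to a fluoro group, gives an at least 3.2-fold higher number from compound 2 to compound 3 (0.50 log units; beyond the scatter), so one added atom on this ring moves the read-out towards weaker inhibition, which the earlier change of the ring on the aromatic nitrogen did not do. The comparison with the 2-(trifluoromethyl)phenyl ring points the same way, with an at least 2.7-fold higher number from compound 1 to compound 3 (0.43 log units; beyond the scatter). Compound 3 stands as a limit of the assay and not a number, so both steps give only a minimum size: the limit of > 40000 nM in this assay, at which 1 of the 3 values shown sits.

The compounds shown leave open how far compound 3 lies past that limit. They also leave open whether the shift belongs to fluoro alone or would also follow from chloro, methoxy or an amine on the same aromatic carbon.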